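Pyrazolopyridine amide series: amine tail changes at the potency limit

A few compounds are considered here, and "the series" means these few. Any claim that something is new, unique, unknown or untested is made for them only; others in the source may bear on it.

Working notes on the amide tail of the shared core. Compound 1 is `O=C(N[C@@H]1CCNC1)c1cc(-c2ccc(NS(=O)(=O)c3cccc(Cl)c3Cl)cc2)nc2[nH]ncc12`. In an assay for inhibition of serine/threonine-protein kinase Sgk1 (Homo sapiens), with stated times of 30 min and 60 min, in the presence of a further agent that is not named here (a higher number here means a weaker inhibitor, a lower number a stronger inhibitor), compound 1 gives < 1 nM, which is a limit of the assay and not a number. Compound 2 is `NCCNC(=O)c1cc(-c2ccc(NS(=O)(=O)c3cccc(Cl)c3Cl)cc2)nc2[nH]ncc12`. In this assay compound 2 gives < 1 nM, again a limit rather than a number. Going by the values given here, the only measured step is therefore a step that the two limits leave unreadable from compound 1 to compound 2; its size cannot be read because both values sit at the limit of < 1 nM in this assay, at which 2 of the 2 values shown sit. Compound 2 thus stands at the floor of what this assay reports, with no readable gradient anywhere in the series.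

Compound 3 is `CCN1CCC(CNC(=O)c2cc(-c3ccc(NS(=O)(=O)c4cccc(Cl)c4Cl)cc3)nc3[nH]ncc23)C1`. It differs from compound 2 by 1-ethylpyrrolidin-3-yl in place of aminomethyl on a saturated chain carbon bound to an amide-type nitrogen. Among the compounds with values here, no measured step bears on this change: the one step in hand is unreadable, and it concerns the same tail region only. With both measured tails at the limit, compound 3 is expected to stay near that floor, at 1 nM with a range of 0.2 nM to 5 nM. The step of a number no lower from compound 2 to compound 3 (the limit leaves the size open) is accordingly expected to fall within the usual scatter.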

Compound 3, half-maximal inhibitory concentration: 109 nM
For compound 3 the middle estimate is 110-fold (2.04 log units) below the measured one, outside the stated range (above it).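

Going by these compounds alone, at the saturated chain carbon bound to an amide-type nitrogen the tail is not free to vary: 1-ethylpyrrolidin-3-yl in place of aminomethyl gives an at least 100-fold higher number from compound 2 to compound 3 (2.03 log units; beyond the scatter) and is the first readable step. Measured from the other tail, (1-ethylpyrrolidin-3-yl)methyl in place of pyrrolidin-3-yl gives an at least 100-fold higher number from compound 1 to compound 3 (2.03 log units; beyond the scatter) in the same direction, so a pyrrolidine ring as such does not set the number, since compound 1 also carries one. Both steps start from limits and not from numbers, and their sizes are open on the upper side because the starting values sit at the floor of what is reported: the limit of < 1 nM in this assay, at which 2 of the 3 values shown sit.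

The compounds shown leave open whether the ethyl group on the ring nitrogen or the added methyl link in the tail accounts for the loss, and the change from compound 1 alters both together. A (pyrrolidin-3-yl)methyl amide with a free ring amine, or a 1-ethylpyrrolidin-3-yl group set directly on the amide nitrogen, would separate the two.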